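A few compounds are considered here, and "the series" means these few. Any claim that something is new, unique, unknown or untested is made for them only; others in the source may bear on it.

Measured compounds:

Compound 1 `Cc1c(O)ccc2c1[C@H](Cn1cc(-c3ccc(F)cc3)nn1)[C@@]13CC(=O)[C@@](C)(CC[C@@H]21)C3` gave > 20000 nM in a functional assay on SW480 cells (Homo sapiens) for cytotoxicity, read by MTT assay, with a stated time of 4 days; on this read-out lower numbers stand for stronger inhibition and higher numbers for weaker inhibition.
Compound 2 `C=C1C[C@]23C[C@@]1(O)CC[C@@H]2c1cccc(C)c1[C@@H]3Cn1cc(-c2ccc(OC)cc2)nn1` gave > 20000 nM in this assay.
Compound 3 `C=C1C[C@]23C[C@@]1(O)CC[C@H]2c1ccc(O)c(C)c1[C@@H]3Cn1cc(-c2ccc(Br)cc2)nn1` gave > 20000 nM in this assay.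

All three values are limits of this assay rather than numbers. For the measured compounds named here, compound 1 stands at the limit of > 20000 nM in this assay, at which 3 of the 3 values shown sit, so nothing separates it from the other two compounds within this set, and no measured pair differs in only one place from which a step could be read.

Compound 4 `Cc1c(O)ccc2c1[C@H](Cn1cc(-c3ccc(C(F)(F)F)cc3)nn1)[C@@]13CC(=O)[C@@](C)(CC[C@@H]21)C3` is the next compound for this assay. It differs from compound 1 in one place: trifluoromethyl in place of fluoro on an aromatic carbon, which is trifluoromethyl in place of fluoro on an aromatic carbon, on a six-membered aromatic ring of carbon only, para to a large group. Going by the values given here, since compound 1 sits at the limit of this assay and no measured step between related compounds is available, the expected step from compound 1 to compound 4 is none beyond the scatter, a step that the limit leaves unreadable from compound 1 to compound 4. Compound 4 is therefore estimated at 30000 nM, with a range from 8000 nM to 100000 nM, and most likely reported again only as a limit in this assay.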

Compound 4, half-maximal inhibitory concentration: > 20000 nM
Compound 4 was reported as a limit; the forecaster's own chance of this, stated with the estimate: 85%; the middle value does not contradict the limit.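

In this assay compound 4 gives > 20000 nM as a limit of the assay. No step from compound 1 to compound 4 can be read, as both values are limits: the limit of > 20000 nM in this assay, at which 4 of the 4 values shown sit.

The compounds shown leave open how strongly any of them acts on these cells, and whether trifluoromethyl and fluoro differ at all.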